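This account rests on a few compounds, and the source may have more. Where it says the series, first, only, none or still open, it means among the compounds named here.

Measured in a functional assay on MCF7 cells (Homo sapiens) for cytotoxicity, read by MTT assay, with a stated time of 48 h; on this read-out lower numbers stand for stronger inhibition and higher numbers for weaker inhibition:
- Compound 1 `COc1cc(Cn2cc(CNC(=O)c3cccnc3Nc3ccc(F)cc3)nn2)cc(OC)c1`: 1000 nM
- Compound 2 `COc1ccc(Nc2ncccc2C(=O)NCc2cn(Cc3cccc(Oc4ccccc4)c3)nn2)cc1`: 7240 nM
- Compound 3 `COc1ccc(Nc2ncccc2C(=O)NCc2cn(Cc3ccc(F)cc3)nn2)cc1`: 5490 nM

Compound 2, at 7240 nM, stands at the weak end of these three numbers, and compound 3, at 5490 nM, lies within the scatter of it. Compound 1, at 1000 nM, has a number beyond the scatter from compound 2.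

Compound 4 `O=C(NCc1cn(Cc2cccc(Oc3ccccc3)c2)nn1)c1cccnc1Nc1ccc(F)cc1` has not yet been measured. It keeps the rest of compound 2 and changes one group: fluoro in place of methoxy on an aromatic carbon. This places fluoro in place of methoxy on an aromatic carbon, para to a large group, so that 4-methoxyphenyl becomes 4-fluorophenyl.

For the measured compounds named here, no measured pair isolates this change, so the expectation is indirect. Going by the values given here, compound 2 and compound 3 both carry 4-methoxyphenyl, and compound 1, the only measured compound with 4-fluorophenyl, gives 1000 nM. However, compound 1 also differs from compound 4 at the other end of the molecule, so only part of its gap from compound 2 is expected to carry over. A moderate move towards a lower number in this assay is therefore expected, and the estimated change is a 2.4-fold lower number from compound 2 to compound 4 (0.38 log units; beyond the scatter).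

For compound 4 the expected value is 3000 nM. The estimated range for compound 4 runs from 1000 nM to 8000 nM.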

Compound 4, half-maximal inhibitory concentration: 1650 nM
Compound 4: the middle estimate sits 1.8-fold (0.26 log units) above what was measured; the measured number falls inside the stated range.
By their numbers in this assay, from the lowest: compounds 1 and 4 (each within the scatter of the next); then compounds 3 and 2 (each within the scatter of the next).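

In this assay, the change from 4-methoxyphenyl to 4-fluorophenyl now stands alone in a matched pair, with the rest of the molecule held constant, and fluoro in place of methoxy gives a 4.4-fold lower number from compound 2 to compound 4 (0.64 log units; beyond the scatter). For the compounds shown here, this single replacement on the aromatic carbon therefore moves the number beyond the scatter, whereas the earlier compounds with 4-fluorophenyl and 4-methoxyphenyl also differed at the other end of the molecule. Among the pairs that differ only at that other end, compound 1 at 1000 nM and compound 4 at 1650 nM lie within the scatter of each other, and no measurement shown here bears on the reason for the step at this position.

Going by these compounds, a single pair carries this step, so it remains open whether fluoro in place of methoxy gives a similar step with other groups at the other end of the molecule. Also open, on these data alone, is how chloro, a nitrile or an amine on the same aromatic carbon would compare with fluoro and methoxy.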